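The source may hold more compounds than are shown below. What is called first, only, known or untested is meant among the compounds shown, and "the series" means these compounds.

Measured compounds:
Compound 1, `Cc1nn2c(C(C)c3ccc(CC(C)C)cc3)nnc2s1`: in a functional assay on the whole organism (strain Wistar albino) for inhibition, with Rattus norvegicus as the target, read by paw edema, with stated times of 30 min and 2 h, at a dose of 20 mg/kg by the oral route (on this read-out lower numbers stand for less inhibition and higher numbers for more inhibition at the one dose given (going by the name of the read-out)), compound 1 gives 58%.
Compound 2, `CCCc1nn2c(C(C)c3ccc(CC(C)C)cc3)nnc2s1`: in this assay compound 2 gives 28%.
Compound 3, `CC(C)Cc1ccc(C(C)c2nnc3sc(-c4ccccc4Cl)nn23)cc1`: in this assay compound 3 gives 59%.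

Compound 3 stands highest of the three in this assay, though its gap to compound 1 lies within the scatter; only compound 2 sits clearly lower, as the step of a number 31 percentage points higher from compound 2 to compound 3 (beyond the scatter) shows. Compound 4, `CC(C)Cc1ccc(C(C)c2nnc3sc(-c4ccc([N+](=O)[O-])cc4Cl)nn23)cc1`, differs from compound 3 by nitro in place of hydrogen on an aromatic carbon.

Among the measured compounds shown here, none of the measured steps touches the 2-chlorophenyl ring itself: a number 30 percentage points lower from compound 1 to compound 2 (beyond the scatter) and a number 1 percentage points higher from compound 1 to compound 3 (within the scatter) concern the group on the shared core, not a substituent on that ring. With no guidance either way, the step of a number 1 percentage points lower from compound 3 to compound 4 (within the scatter) is expected to stay within the scatter. Compound 4 is therefore estimated at 58%, between 42% and 74%.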

Compound 4, a percentage reported as inhibition, in the whole organism at one dose (the size of the read-out at that dose, not a potency): 67%
Compound 4: middle estimate off by 9 percentage points, on the low side; the measured number falls inside the stated range.
By their numbers in this assay, from the lowest: compound 2; then compounds 1, 3 and 4 (each within the scatter of the next).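

In this assay, the ring position para to a large group and meta to a chloro group accepts a nitro group with no change beyond the scatter (a number 8 percentage points higher from compound 3 to compound 4 (within the scatter)). Replacing the methyl of the shared core with the whole 2-chloro-4-nitrophenyl group likewise stays within the scatter (a number 9 percentage points higher from compound 1 to compound 4 (within the scatter)), while replacing the propyl gives a large step (a number 39 percentage points higher from compound 2 to compound 4 (beyond the scatter)). Nothing available explains these numbers. Going by these compounds, what an amine or a carboxylic acid would give at this position remains open. So does whether nitro would read the same on a phenyl ring without the chloro group.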